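The compounds below may be only part of what the source reports. "The series", "measured", "known", "first", "only" and "open" are said of these compounds alone.

Measured so far in a functional assay on HeLa cells (Homo sapiens) for antiproliferative activity, read by MTT assay, with a stated time of 48 h; on this read-out higher numbers stand for weaker inhibition and lower numbers for stronger inhibition:
- compound 1 `COc1ccc(C(=O)c2ccc3c(c2)C=CC(C)(C)O3)c(NC(=O)CBr)c1` gives 3050 nM
- compound 2 `COc1ccc(C(=O)c2ccc3c(c2)C=CC(C)(C)O3)c(NC(=O)CO)c1` gives 240 nM
- compound 3 `CNCC(=O)Nc1cc(OC)ccc1C(=O)c1ccc2c(c1)C=CC(C)(C)O2` gives 970 nM

These three share one core and differ only in the group on a saturated chain carbon bound to a carbonyl carbon, which is bromo, hydroxy or methylamino. Compound 3, with 970 nM as its number, sits in the middle of the three. Its neighbours lie beyond the scatter on both sides, as a 3.1-fold lower number from compound 1 to compound 3 (0.50 log units; beyond the scatter) and a 4.0-fold higher number from compound 2 to compound 3 (0.61 log units; beyond the scatter) show. The widest swap at that carbon is a 13-fold lower number from compound 1 to compound 2 (1.10 log units; beyond the scatter) and counts as large.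

Compound 4 `COc1ccc(C(=O)c2ccc3c(c2)C=CC(C)(C)O3)c(NC(=O)CN(C)C)c1` differs from compound 3 by methyl in place of hydrogen on an amine nitrogen which turns methylamino into dimethylamino. Going by the values given here, none of the measured steps makes this change. All three replace the whole group on the chain carbon, so they bear on it only loosely. As far as these compounds go, compound 4 keeps the amine nitrogen of compound 3, so no step beyond the scatter is expected in this assay and the direction stays open. The expected step is a 1.1-fold lower number from compound 3 to compound 4 (0.03 log units; within the scatter) and would lie within the scatter. For compound 4 the estimated value is 900 nM with 300 nM to 2700 nM as its expected range.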

Compound 4, half-maximal inhibitory concentration: 1260 nM
Compound 4: the middle estimate sits 1.4-fold (0.15 log units) below what was measured; the range from low to high includes it.
By their numbers in this assay, from the lowest: compound 2; then compounds 3 and 4 (each within the scatter of the next); then compound 1.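

In this assay, methyl in place of hydrogen on the amine nitrogen, which turns methylamino into dimethylamino, leaves two values that cannot be told apart, with a 1.3-fold higher number from compound 3 to compound 4 (0.11 log units; within the scatter) as the step between them. Dimethylamino also takes up the same middle place as methylamino among the groups on this chain carbon: dimethylamino in place of hydroxy gives a 5.3-fold higher number from compound 2 to compound 4 (0.72 log units; beyond the scatter) and the swap for bromo gives a 2.4-fold lower number from compound 1 to compound 4 (0.38 log units; beyond the scatter) as its step, so at this position hydroxy keeps the lowest number and bromo the highest, whichever of the two amines is compared. No measurement among these compounds offers a reason for this order, or for the two amines matching.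

The compounds shown do not tell whether the match between the two amines would hold for a larger group on the nitrogen, such as diethylamino, or for the plain amino group at the other end of the series. They also leave open how methoxy would compare with hydroxy on this carbon, and whether a longer chain between the carbonyl and the amine would keep the same order.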